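The source may hold more compounds than are shown below. What is called first, only, known or untested is meant among the compounds shown, and "the series" means these compounds.

Measured so far in a functional assay on MGC-803 cells (Homo sapiens) for antiproliferative activity, read by CCK-8 assay, with a stated time of 72 h; on this read-out higher numbers stand for weaker inhibition and lower numbers for stronger inhibition:

compound 1, `Nc1ccccc1NC(=O)/C=C/c1ccc(CN2CCc3ccccc32)cc1`: > 32000 nM
compound 2, `Nc1ccccc1NC(=O)c1ccc(CN2CCc3cc(Br)ccc32)cc1`: 7390 nM
compound 3, `Nc1ccccc1NC(=O)c1ccc(COc2ccc(F)cc2)cc1`: 4970 nM

The value of compound 1 is a limit of this assay and not a number, as noted in the limit of > 32000 nM in this assay, at which 1 of the 3 values shown sits. Of the two numbers shown, compound 3 and compound 2 lie within the usual scatter of each other, so neither can be set apart on these data.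

Compound 4, `COc1ccc(OCc2ccc(C(=O)Nc3ccccc3N)cc2)cc1`, differs from compound 3 in one place: methoxy in place of fluoro on an aromatic carbon. For the measured compounds named here, no measured pair shows this change, so its size in this assay is unknown. Nothing in the measured compounds points to a shift beyond the scatter in either direction. Compound 4 is therefore expected to give about 5000 nM, within 2000 nM to 13000 nM, a step of a 1.0-fold higher number from compound 3 to compound 4 (0.00 log units; within the scatter) that is expected to stay within the scatter.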

Compound 4, half-maximal inhibitory concentration: 3480 nM
Compound 4: middle estimate off by 1.4-fold (0.16 log units), on the high side, within the range that was stated.
By their numbers in this assay, from the lowest: compounds 4, 3 and 2 (each within the scatter of the next, the first and the last beyond it). At a limit, above all of these: compound 1.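

In this assay, for the compounds shown here, methoxy in place of fluoro on an aromatic carbon gives a 1.4-fold lower number from compound 3 to compound 4 (0.15 log units; within the scatter) as the first measured pair at this position. The position para to a large group thus takes 4-methoxyphenyl as well as 4-fluorophenyl, and the added hydrogen-bond acceptor and extra heavy atom leave the two compounds not separable on this read-out. Nothing in the data shown bears on a cause for this step.

On these data alone, whether an amine, a carboxylic acid or a longer chain at this position would give a step beyond the scatter remains open.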